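Swapping the aryl group on a shared alkene core

The source may report more compounds than this note shows. Statements on the series, on what has been measured and on what is new or still open speak of the compounds shown alone.

Of the compounds shown here, three sharing one core have been tested in a functional assay on MCF7 cells (Homo sapiens) for inhibition; on this read-out lower numbers stand for stronger inhibition and higher numbers for weaker inhibition. Compound 1 `CC/C(=C(/c1ccc(/C=C/C(=O)O)cc1)c1cc2ccccc2[nH]1)c1ccccc1Cl` gives 42 nM. Compound 2 `CC/C(=C(/c1ccc(/C=C/C(=O)O)cc1)c1cc2ccccc2[nH]1)c1cccc(OC(F)(F)F)c1`, which carries 3-(trifluoromethoxy)phenyl instead, gives 282 nM, and a 6.7-fold higher number from compound 1 to compound 2 (0.83 log units; beyond the scatter). Compound 3 `CC/C(=C(/c1ccc(/C=C/C(=O)O)cc1)c1cc2ccccc2[nH]1)c1cccc(F)c1C#N` gives 40 nM; the step of a 1.1-fold lower number from compound 1 to compound 3 (0.02 log units; within the scatter) shows that compound 3 and compound 1 cannot be told apart, whereas a 7.1-fold lower number from compound 2 to compound 3 (0.85 log units; beyond the scatter). Compound 3 thus has the lowest number of the three, but only its gap to compound 2 is meaningful.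

Compound 4 `CC/C(=C(/c1ccc(/C=C/C(=O)O)cc1)c1cc2ccccc2[nH]1)c1ccc(Cl)cc1Cl` is the next variant at the same place: 2,4-dichlorophenyl in place of 2-cyano-3-fluorophenyl on a double-bonded chain carbon bound to a double-bonded chain carbon and a saturated chain carbon. All three measured steps bear on this, since each also exchanges the aryl group on that carbon. Two of them, between compound 1 and compound 3, stayed within the scatter, and only the move to 3-(trifluoromethoxy)phenyl in compound 2 cost potency. Among the measured groups, the 2-chlorophenyl of compound 1 is the closest relative of 2,4-dichlorophenyl, so a number near that of compound 1 and compound 3 is expected, with some risk of a modest rise. The expected step is a 1.4-fold higher number from compound 3 to compound 4 (0.14 log units; within the scatter). For compound 4 the estimated value is 55 nM, within a range from 20 nM to 160 nM.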

Compound 4, half-maximal inhibitory concentration: 11 nM
For compound 4 the middle estimate is 5.0-fold (0.70 log units) above the measured one; the measured number lies below the stated range.
By their numbers in this assay, from the lowest: compound 4; then compounds 3 and 1 (each within the scatter of the next); then compound 2.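

This result shows that the aryl group on this carbon can do better than the level shared by compound 1 and compound 3. For the compounds shown here, the cleanest comparison is the single change of chloro in place of hydrogen on an aromatic carbon, which gives a 3.8-fold lower number from compound 1 to compound 4 (0.58 log units; beyond the scatter) in this assay; the same level is also passed in the wider exchange of 2-cyano-3-fluorophenyl for 2,4-dichlorophenyl, with a 3.6-fold lower number from compound 3 to compound 4 (0.56 log units; beyond the scatter). The span among the groups at this place also grows to a large one, with a 26-fold lower number from compound 2 to compound 4 (1.41 log units; beyond the scatter), though no measurement here explains any of these differences.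

On these data alone, it remains open whether the added chloro is itself needed, or whether a fluoro, a methyl or a methoxy in its place on the 2,4-dichlorophenyl would give a similarly low number. As far as these compounds go, it is also open whether a chloro added to the 2-cyano-3-fluorophenyl of compound 3 would lower the number in the same way.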